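The source may report more compounds than this note shows. Statements on the series, on what has been measured and on what is new or still open speak of the compounds shown alone.

Measured compounds:
- compound 1, `COc1cc(-c2cc(/C=C/C(=O)c3ccc(N)cc3)[nH]n2)cc(OC)c1OC`: 57%
- compound 2, `COc1ccc(-c2cc(/C=C/C(=O)c3ccc(N)cc3)[nH]n2)cc1OC`: 88%
- compound 3, `COc1cc(C(=O)/C=C/c2cc(-c3cc(OC)c(OC)c(OC)c3)n[nH]2)cc(OC)c1OC`: 79%

All three were tested in a functional assay on KM12 cells (Homo sapiens) for cytotoxicity, read by sulforhodamine B assay, with a stated time of 48 h, tested at 1 uM; on this read-out lower numbers stand for a stronger effect and higher numbers for a weaker effect at the one concentration tested. Compound 1 gives 57% in this assay, and compound 2 gives 88%. The change from compound 1 to compound 2 is this one:

hydrogen in place of methoxy on an aromatic carbon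

That step produced a number 31 percentage points higher from compound 1 to compound 2 (beyond the scatter).

Compound 3 belongs to a different core; how it differs from compound 1 is not broken down here. In this assay compound 3 gives 79%. Its value is within the scatter of compound 2, and beyond it compared with compound 1.

Compound 4, `COc1ccc(-c2cc(/C=C/C(=O)c3cc(OC)c(OC)c(OC)c3)[nH]n2)cc1OC`, has not yet been measured. It is made from compound 3 by the following change:

hydrogen in place of methoxy on an aromatic carbon

Going by the values given here, this is the same change as the one from compound 1 to compound 2, at a place described in the same words. On the first core that change gave a large increase. The same kind of step is expected on the core of compound 3, but compound 3 already gives 79%, so the room for a further increase is smaller than it was for compound 1. For compound 4 a step of a number 16 percentage points higher from compound 3 to compound 4 (beyond the scatter) is therefore expected in this assay. Among the compounds with values here, the estimate for compound 4 in this assay is 95%, with a range from 80% to 110%; this rests on the one earlier step only, so it is held with limited confidence.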

Compound 4, a percentage reported as activity, at one concentration (the size of the read-out at that concentration, not a potency): 45%
Beside the measured number, compound 4's estimate is 50 percentage points above it; the measured number lies below the stated range.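

On the core of compound 3, hydrogen in place of methoxy on an aromatic carbon gave a number 34 percentage points lower from compound 3 to compound 4 (beyond the scatter) in this assay, so a lower number stands where the core of compound 1 had given a higher one. The effect of this change therefore did not carry from one core to the other in this series, in direction or as a shared step: the same change on two cores in this assay, a number 31 percentage points higher (beyond the scatter) from compound 1 to compound 2 and a number 34 percentage points lower (beyond the scatter) from compound 3 to compound 4, 65 percentage points apart, beyond the scatter of two such steps This shows that the outcome of the change depends on the core in these two pairs, but it does not show which part of the core is responsible or why the direction differs, and two pairs give no rule for any further core.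

The compounds shown leave open what other groups would do at this aromatic carbon on either core, such as a hydroxy group, a fluorine atom or an ethoxy group, and whether any of them would follow the step seen on the core of compound 1 or the one seen on the core of compound 3. They also leave open whether the two opposite steps would hold at other concentrations, as each read-out here comes from a single concentration and is not a potency.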